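The compounds below may be only part of what the source reports. "The series", "measured", "known", "first", "only" and "open" are said of these compounds alone.

Measured in a functional assay on A2780 cells (Homo sapiens) for antiproliferative activity, read by resazurin assay, with a stated time of 72 h; on this read-out lower numbers stand for stronger inhibition and higher numbers for weaker inhibition:
- compound 1 `Cc1cccc(CN(C)C(=O)c2cc3c(Cc4ccccc4)n[nH]c3cc2O)c1`: "not determined" (no result reported)
- compound 2 `CN(Cc1ccc(Br)cc1)C(=O)c1cc2c(Cc3ccccc3)n[nH]c2cc1O`: 2800 nM
- compound 3 `Cc1ccc(CN(C)C(=O)c2cc3c(Cc4ccccc4)n[nH]c3cc2O)cc1`: 6900 nM

Going by the values given here, compound 3 has the higher of the only two numbers available, which makes it the weaker of the pair. Compound 1 offers no number for comparison.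

The next change leads to compound 4 `COc1cc(CN(C)C(=O)c2cc3c(Cc4ccccc4)n[nH]c3cc2O)ccc1Cl`: 4-chloro-3-methoxyphenyl in place of 4-methylphenyl on a saturated chain carbon bound to an amide-type nitrogen. In words, this is 4-chloro-3-methoxyphenyl in place of 4-methylphenyl on a saturated chain carbon bound to an amide-type nitrogen.

Among the compounds with values here, one measured step bears on it: a 2.5-fold higher number from compound 2 to compound 3 (0.39 log units; beyond the scatter). This modest step came with methyl in place of bromo on an aromatic carbon. Read in reverse, it gives some support for a lower number when the methyl of compound 3 gives way to a halogen, though chloro itself has not been measured in this series. Within the data shown here, no measured compound carries a methoxy group, so that part of the change remains untested. The evidence is therefore a single pair, and a modest shift toward a lower number in this assay is expected, no larger than the measured step.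

The expected change is a 1.8-fold lower number from compound 3 to compound 4 (0.26 log units; within the scatter).

Compound 4 is estimated at 3800 nM, with an expected range of 1500 nM to 9000 nM.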

Compound 4, half-maximal inhibitory concentration: 4100 nM
The estimate for compound 4 lay 1.1-fold (0.03 log units) below the measured number; measured number inside the range.
By their numbers in this assay, from the lowest: compounds 2, 4 and 3 (each within the scatter of the next, the first and the last beyond it).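

In this assay, 4-chloro-3-methoxyphenyl in place of 4-methylphenyl on a saturated chain carbon bound to an amide-type nitrogen gives a 1.7-fold lower number from compound 3 to compound 4 (0.23 log units; within the scatter), and the same group in place of 4-bromophenyl gives a 1.5-fold higher number from compound 2 to compound 4 (0.17 log units; within the scatter). Going by these compounds alone, this place therefore carries the larger 4-chloro-3-methoxyphenyl group, which brings in a hydrogen-bond acceptor, with no step beyond the scatter to either neighbour, and the only step beyond the scatter so far remains the one separating compound 2 from compound 3. No measured information is available to explain these numbers.

The separate contributions of chloro and methoxy remain unresolved: compound 4 carries both, and neither appears alone on this ring in the compounds with a number. Also open, on these data alone, is whether an amine or a carboxylic acid on this aromatic ring, or a longer chain in place of the saturated chain carbon, would move the number beyond the scatter.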